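A few compounds are considered here, and "the series" means these few. Any claim that something is new, unique, unknown or untested is made for them only; others in the source may bear on it.

Working notes on the series in an ADME assay on RAW264.7 cells (Mus musculus) for cytotoxicity, read by MTT assay, with a stated time of 24 h, tested at 2.5 ug/mL; on this read-out higher numbers stand for a weaker effect at the one concentration tested and lower numbers for a stronger effect.

Of the compounds shown here, three have a number so far. Compound 1 `COc1cc(/C=C/C(=O)c2cccc(O)c2)ccc1O` gives 94%. Compound 2 `COc1ccc(CCC(=O)c2cccc(O)c2)cc1` gives 97.1%. Compound 3 `COc1ccc(CCCc2ccc(OC)cc2OC)c(O)c1` gives 97.7%. On these numbers compound 2 sits second of three, with compound 3 as its nearest neighbour and compound 1 as its furthest, but both gaps lie within the scatter of repeated measurements, so the three read as one level of weak effect at the single concentration tested and no order among them is claimed.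

Compound 4 `COc1ccc(CCC(=O)c2cccc(O)c2)c(OC)c1` is the next compound to be measured. Set against compound 2 it carries one change: methoxy in place of hydrogen on an aromatic carbon. Among the measured compounds shown here, no measured pair in this set differs in one place, so there is no comparable step to lean on. The three measured compounds, which differ from one another in several places at once, all land in the same narrow band, which gives no hint that a single added methoxy would move the read-out beyond the scatter. The step in this assay from compound 2 to compound 4 is therefore expected to be none beyond the scatter, a number 1.1 percentage points lower from compound 2 to compound 4 (within the scatter). For compound 4 the estimate is 96%, with a range from 89% to 101%.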

Compound 4, a percentage reported as activity, at one concentration (the size of the read-out at that concentration, not a potency): 88.5%
For compound 4 the middle estimate is 7.5 percentage points above the measured one; measured number outside the range, below it.
By their numbers in this assay, from the lowest: compounds 4, 1, 2 and 3 (each within the scatter of the next).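

In this assay, among the compounds shown here, methoxy in place of hydrogen on an aromatic carbon, ortho to a large group and meta to a methoxy group, gives the first step that can be read at a single place: a number 8.6 percentage points lower from compound 2 to compound 4 (within the scatter). This pair therefore gives no ground for saying that adding a methoxy group at this position alters the read-out at the one concentration tested, although a single pair at a single concentration cannot rule out a real effect of this size. Nothing available explains the step or bears on how this position acts in the assay.

Still open, going by these compounds, is whether an amine or a carboxylic acid on the same aromatic carbon would give a step beyond the scatter, and whether a methoxy group on another carbon of that ring would read the same way. With one concentration only, the numbers also leave open how compound 2 and compound 4 would compare at other concentrations or over a different exposure time.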